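The source may hold more compounds than are shown below. What is called first, only, known or untested is meant among the compounds shown, and "the series" means these compounds.

Of the compounds shown here, three have so far been measured in an ADME assay on microsomes from liver (Mus musculus, strain NMRI) for metabolic stability, tested at 2.5 uM; on this read-out higher numbers stand for fast clearance and lower numbers for slow clearance. Compound 1 `c1ccc(-c2ccc(Cn3nnc4ccccc43)cc2)cc1` gives 11.4 mL/min/g. Compound 2 `Brc1cccc2c1nnn2CC1CCCC1` gives 11.4 mL/min/g, and compound 3 `Brc1cccc2c1nnn2CC1CC1` gives 7.7 mL/min/g. Compound 3 carries the lowest of these three numbers, but its gaps to compound 1 and to compound 2 both lie within the usual scatter of repeated measurements, so on these numbers the three compounds cannot be told apart.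

Compound 4 `CCCn1nnc2c(Br)cccc21` has not yet been measured. It differs from compound 3 in one place: ethyl in place of cyclopropyl on a saturated chain carbon bound to an aromatic nitrogen. Among the compounds with values here, only one measured step bears on a change of this kind. From compound 2 to compound 3 the cyclopentyl group on that same saturated chain carbon was replaced by cyclopropyl, and the number moved a 1.5-fold lower number from compound 2 to compound 3 (0.17 log units; within the scatter), a step that stays within the scatter. Exchanging one small ring on that carbon for another thus left the read-out essentially where it was, and putting a small chain in place of a small ring is a change of similar size. The estimate for compound 4 in this assay is therefore 9 mL/min/g, with a range from 5 mL/min/g to 16 mL/min/g. That estimate means a step of a 1.2-fold higher number from compound 3 to compound 4 (0.07 log units; within the scatter), expected to fall within the scatter.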

Compound 4, intrinsic clearance in a liver preparation (reported as CLH), per the amount of preparation that the assay uses: 7.7 mL/min/g
Compound 4: middle estimate off by 1.2-fold (0.07 log units), on the high side, and the stated range covers the measured number.
By their numbers in this assay, from the lowest: compounds 3, 4, 1 and 2 (each within the scatter of the next).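

In this assay, ethyl in place of cyclopropyl gives no change at the digits printed from compound 3 to compound 4 (within the scatter) at this place, a saturated chain carbon bound to an aromatic nitrogen, which shows that the ring itself can be given up without a change that can be told from the scatter. Within the data shown here, until now the only step at this place had exchanged one ring for another, whereas an open chain can now be set against the larger ring as well: ethyl in place of cyclopentyl gives a 1.5-fold lower number from compound 2 to compound 4 (0.17 log units; within the scatter) and so also stays inside what repeated measurements would show. Across compounds 2, 3 and 4, then, cyclopentyl, cyclopropyl and ethyl cannot be told apart on this read-out, and no separate measurement is at hand to explain that result.

On these data alone, every group compared here is built of carbon and hydrogen alone, so it remains open whether an amine, a carboxylic acid or a much longer chain at this place would leave the number as undisturbed. Compounds 2, 3 and 4 also all keep the bromine on the shared core, and whether exchanging that bromine for a chlorine or a nitrile would shift the read-out is equally unanswered.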